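Cytotoxicity notes: a benzodioxinyl variant of the biaryl amide series

A few compounds are considered here, and "the series" means these few. Any claim that something is new, unique, unknown or untested is made for them only; others in the source may bear on it.

Measured so far:
- compound 1 `CCOC(=O)CCCCCOc1cccc(CN(C(=O)c2ccc(-c3ccco3)cc2)C(C)C)c1`: > 26000 nM
- compound 2 `CCOC(=O)CCCCCOc1cccc(CN(C(=O)c2ccc(-c3cccc(OCC)c3)cc2)C(C)C)c1`: > 22300 nM

In an ADME assay on HEK293 cells (Homo sapiens) for cytotoxicity, read by CellTiter-Glo and resazurin assay, with a stated time of 72 h (on this read-out lower numbers stand for an effect already at smaller amounts and higher numbers for an effect only at larger amounts of compound), compound 1 gives > 26000 nM, a limit of the assay. In the same assay compound 2 gives > 22300 nM, likewise a limit. The step that the two limits leave unreadable from compound 1 to compound 2 is therefore unreadable in size. Compound 2 stands at the limit (the limit of > 22300 nM in this assay, at which 1 of the 2 values shown sits); compound 1 sits at the other limit (the limit of > 26000 nM in this assay, at which 1 of the 2 values shown sits). Compound 3 `CCOC(=O)CCCCCOc1cccc(CN(C(=O)c2ccc(-c3ccc4c(c3)OCCO4)cc2)C(C)C)c1` differs from compound 2 by 2,3-dihydro-1,4-benzodioxin-6-yl in place of 3-ethoxyphenyl on an aromatic carbon. Among the compounds with values here, the only measured step at this aromatic carbon, a step that the two limits leave unreadable from compound 1 to compound 2, gives no size, so no step beyond the scatter is expected in either direction. Compound 3 is thus expected at 30000 nM, between 10000 nM and 100000 nM. The expected step is a step that the limit leaves unreadable from compound 2 to compound 3.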

Compound 3, half-maximal effective concentration: > 24400 nM
Compound 3 gave a limit, no number; the forecaster's own chance of this, stated with the estimate: 75%; the middle value is on the limit's open side.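

Compound 1, compound 2 and compound 3 all give limits, not numbers, in this assay, so none of the steps among them can be read. The compounds shown leave open whether exchanging the aromatic group changes cytotoxicity at all.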